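Azaindole in Place of Trifluoromethylphenyl on an Imidazole Core

The source may hold more compounds than are shown below. What is called first, only, known or untested is meant among the compounds shown, and "the series" means these compounds.

Compound 1, `O=C1COc2ccc(-c3[nH]c(-c4ccc(C(F)(F)F)cc4)nc3-c3ccccc3)cc2N1`, carries a 4-(trifluoromethyl)phenyl group on its five-membered ring. In a functional assay on DLD-1 cells (Homo sapiens) for cytotoxicity, read by colorimetric assay and MTT assay, with a stated time of 3 days, tested at 20 uM (a higher number here means a weaker effect of the compound at the concentration tested, a lower number a stronger effect), compound 1 gives 12.1%, the lowest of the three numbers recorded, and so the strongest effect among them. Compound 2, `O=C1COc2ccc(-c3nn(-c4ccc(F)cc4)cc3-c3ccccc3)cc2N1`, gives 45.2% in this assay, and compound 3, `O=C1COc2ccc(-c3nn(-c4ccc(Cl)cc4)cc3-c3ccccc3)cc2N1`, gives 47.1%; both stand beyond the scatter above compound 1. Among the measured compounds shown here, the only step between measured compounds that differ in one place is a number 1.9 percentage points higher from compound 2 to compound 3 (within the scatter), and it concerns a halogen swap on a different core, not the change that matters here.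

Compound 4, `O=C1COc2ccc(-c3[nH]c(-c4c[nH]c5ncccc45)nc3-c3ccccc3)cc2N1`, is derived from compound 1 by the following change: a group of 9 heavy atoms (7 carbon, 2 nitrogen; one five-membered aromatic ring with 1 hetero atom, one six-membered aromatic ring with 1 hetero atom) in place of a group of 10 heavy atoms (7 carbon, 3 fluorine; one six-membered aromatic ring of carbon only), on an aromatic carbon. For the measured compounds named here, no measured pair shows what exchanging the aryl group at this position of the shared core does, so the expectation rests on compound 1 alone with wide uncertainty. The estimate for compound 4 is 25%, with a range from 8% to 55%. This estimate corresponds to an expected step of a number 12.9 percentage points higher from compound 1 to compound 4 (beyond the scatter), leaning toward a somewhat weaker effect, though a number close to compound 1 remains plausible.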

Compound 4, a percentage reported as activity, at one concentration (the size of the read-out at that concentration, not a potency): 53.5%
Compound 4: the middle estimate sits 28.5 percentage points below what was measured; the measured number falls inside the stated range.
By their numbers in this assay, from the lowest: compound 1; then compounds 2, 3 and 4 (each within the scatter of the next).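

In this assay, among the compounds shown here, putting the two-ring group in place of the 4-(trifluoromethyl)phenyl group gives a number 41.4 percentage points higher from compound 1 to compound 4 (beyond the scatter), the first measured step at this position of the shared core. For the compounds shown here, the only earlier step was a halogen swap on a different core, whereas this large step shows that the effect seen with compound 1 at the tested concentration depends strongly on the group carried on this aromatic carbon between two ring nitrogen atoms, and that it does not survive this exchange. No measurement among those shown bears on what lies behind this step.

The exchange alters several things at once: the trifluoromethyl group leaves, a single ring of carbon only gives way to two rings that each hold a hetero atom, and a hydrogen-bond donor and a hydrogen-bond acceptor enter, so the compounds shown cannot say which of these changes accounts for the step. From the compounds shown here alone, an unsubstituted phenyl group or a 4-methoxyphenyl group on the same core would begin to separate them, and whether any other group at this position matches compound 1 remains open.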